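This account rests on a few compounds, and the source may have more. Where it says the series, first, only, none or still open, it means among the compounds named here.

Compound 1, `Fc1cccc(Cn2ccc3nc(-c4ccccc4)nc-3c2)c1`, is the starting point of this step. In an ADME assay on MDBK cells (Bos taurus) for cytotoxicity (a higher number here means that more compound is tolerated, a lower number that less compound is tolerated), compound 1 gives > 100000 nM, which is a limit of the assay rather than a number. Its nearest measured neighbour, compound 2, `FC(F)(F)c1cccc(Cn2ccc3nc(-c4ccccc4)nc-3c2)c1`, gives 98000 nM in this assay. The step of an at least 1.0-fold lower number from compound 1 to compound 2 (0.00 log units; that floor lies within the scatter) therefore does not rise above the scatter of this assay. Compound 3, `CC(c1ccccc1)n1ccc2nc(-c3ccccc3)nc-2c1`, gives > 100000 nM in this assay, again a limit. Across the three measured compounds, (the limit of > 100000 nM in this assay, at which 2 of the 3 values shown sit).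

Compound 4 is `c1ccc(-c2nc3ccn(CC4CCCCC4)cc-3n2)cc1`. The change from compound 1 is cyclohexyl in place of 3-fluorophenyl on a saturated chain carbon bound to an aromatic nitrogen. Among the measured compounds shown here, no measured step covers this exchange; the only measured step, from compound 1 to compound 2, concerns a different position and lies within the scatter. All three measured values sit at or near the same level, so no step beyond the scatter is expected for compound 4 in this assay. Compound 4 is expected to give about 100000 nM, between 45000 nM and 200000 nM. The expected step is a number no higher from compound 1 to compound 4 (the limit leaves the size open).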

Compound 4, half-maximal cytotoxic concentration: > 100000 nM
Compound 4: no number, only a limit; the forecaster's own chance of this, stated with the estimate: 55%; the middle value lies on the limit itself.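

The step from compound 1 to compound 4 cannot be read, since both values are limits of this assay and not numbers: the limit of > 100000 nM in this assay, at which 3 of the 4 values shown sit.

The compounds shown leave open whether cyclohexyl in place of 3-fluorophenyl changes the concentration tolerated in this assay at all.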